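The compounds below may be only part of what the source reports. "The series", "measured", "known", "first", "only" and "open" are said of these compounds alone.

In an ADME assay on the whole organism for pharmacokinetics, with Rattus norvegicus as the target (on this read-out lower numbers stand for lower oral bioavailability and higher numbers for higher oral bioavailability), compound 2 `COc1cc([C@H](c2cc3cc(Br)ccc3nc2OC)[C@@](O)(CCN(C)C)c2cccc(F)c2)cnc1OC` gives 36%. Among the compounds with values here, the only other measured compound, compound 1 `COc1nc2ccc(Br)cc2cc1[C@@H](c1ccc(N(C)C)nc1)[C@@](O)(CCN(C)C)c1cccc(F)c1`, gives 45%, so these two numbers lie within the usual scatter of each other. Compound 3 `CCSc1ccc([C@H](c2cc3cc(Br)ccc3nc2OC)[C@@](O)(CCN(C)C)c2cccc(F)c2)cn1` keeps the rest of compound 2 and alters one group on a saturated chain carbon bound to an aromatic carbon and a saturated chain carbon: 6-(ethylsulfanyl)pyridin-3-yl in place of 5,6-dimethoxypyridin-3-yl on a saturated chain carbon bound to an aromatic carbon and a saturated chain carbon. In words, 6-(ethylsulfanyl)pyridin-3-yl stands in place of 5,6-dimethoxypyridin-3-yl. Within the data shown here, one measured step bears on this, an exchange at the same place, and it gave a number 9 percentage points lower from compound 1 to compound 2 (within the scatter). Among the measured compounds shown here, no compound with the incoming group has been measured, so this single step gives only a rough guide and no clear direction. The expected step of a number 1 percentage points lower from compound 2 to compound 3 (within the scatter) is therefore no larger than the scatter. For compound 3 the estimated value is 35%, with an expected range of 18% to 52%.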

Compound 3, oral bioavailability: 30%
Beside the measured number, compound 3's estimate is 5 percentage points above it; the range from low to high includes it.
By their numbers in this assay, from the lowest: compounds 3, 2 and 1 (each within the scatter of the next, the first and the last beyond it).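

Across the three groups now seen on this saturated chain carbon, a number 6 percentage points lower from compound 2 to compound 3 (within the scatter) shows that 6-(ethylsulfanyl)pyridin-3-yl and 5,6-dimethoxypyridin-3-yl cannot be told apart in this assay by this exchange alone. Within the data shown here, the exchange of dimethylamino for ethylsulfanyl on an aromatic carbon gives a number 15 percentage points lower from compound 1 to compound 3 (beyond the scatter) and is the first step here to pass the scatter, although only modestly, so two steps that each stay within the scatter can still add up to a real gap. No measurement offered here explains this gap.

An ethoxy group or a morpholine ring on that same aromatic carbon could show whether other replacements for dimethylamino give a similar result. As far as these compounds go, it also remains open whether a methylsulfanyl or propylsulfanyl group would shift the number compared with ethylsulfanyl.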